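The compounds below may be only part of what the source reports. "The series", "measured", "known", "first", "only" and "open" are said of these compounds alone.

In a functional assay on Caco-2 cells (Homo sapiens) for inhibition, read by sulforhodamine B assay, with a stated time of 48 h (on this read-out lower numbers stand for stronger inhibition and higher numbers for weaker inhibition), compound 3 `CCO[C@H]1C[C@@H](c2coc3ccccc3c2=O)N(c2ccccc2)O1` gives > 60000 nM, which is a limit of the assay rather than a number. Compound 1 `CCO[C@H]1C[C@@H](c2coc3ccc(Br)cc3c2=O)N(c2ccccc2)O1` gives > 60000 nM, likewise only a limit. The single-point step between these two, hydrogen in place of bromo on an aromatic carbon, is a step that the two limits leave unreadable from compound 1 to compound 3, because both values sit at the limit of > 60000 nM in this assay, at which 2 of the 3 values shown sit. Within the data shown here, the only numbered value among the three belongs to compound 2 `Cc1ccc2occ([C@@H]3C[C@H](c4ccccc4)ON3c3ccccc3)c(=O)c2c1`, which in this assay gives 31700 nM; it shares no single-point step with compound 3, so its value stands on its own. Compound 4 `CCO[C@H]1C[C@@H](c2coc3ccc(C)cc3c2=O)N(c2ccccc2)O1` differs from compound 3 by methyl in place of hydrogen on an aromatic carbon. Among the measured compounds shown here, no measured step bears directly on this change: the one step available, from compound 1 to compound 3, is unreadable, and the methyl-bearing compound 2 differs from compound 4 in more than one place. The step of a number no higher from compound 3 to compound 4 (the limit leaves the size open) is therefore expected to show no direction beyond the scatter. Compound 4 is expected, like compound 3, to return most likely only a limit, or at best a weak number near it. The estimate for compound 4 is 60000 nM, with a range from 20000 nM to 200000 nM.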

Compound 4, half-maximal inhibitory concentration: 31000 nM
Beside the measured number, compound 4's estimate is 1.9-fold (0.29 log units) above it, within the range that was stated.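

With methyl on the aromatic carbon that is meta to a fused ring and para to a fused ring, compound 4 alone among the ethoxy-bearing compounds shown gives a number rather than a limit in this assay; the step is an at least 1.9-fold lower number from compound 3 to compound 4 (0.28 log units; that floor lies within the scatter). Methyl set against bromo at the same carbon reads the same way, an at least 1.9-fold lower number from compound 1 to compound 4 (0.28 log units; that floor lies within the scatter), and the bromo and hydrogen compounds both remain at a limit: the limit of > 60000 nM in this assay, at which 2 of the 4 values shown sit. The change on the saturated ring carbon, with the methyl held in place, is a 1.0-fold lower number from compound 2 to compound 4 (0.01 log units; within the scatter), so the two methyl-bearing compounds do not separate, whether that carbon carries ethoxy or phenyl.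

The true distance of compound 1 and compound 3 from compound 4 stays open, and the compounds shown do not settle whether methyl at this position counts for more than the scatter. They also leave open what an amine or a longer chain on this aromatic carbon would give in this assay.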